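A few compounds are considered here, and "the series" means these few. Any claim that something is new, unique, unknown or untested is made for them only; others in the source may bear on it.

In an assay on CHO cells for displacement of a labelled ligand from transient receptor potential cation channel subfamily V member 1 (Homo sapiens) (a lower number here means a stronger inhibitor, a higher number a weaker inhibitor), compound 2 `CC1CCN(c2nc(C(F)(F)F)ccc2CNC(=O)Nc2ccc3cc[nH]c(=O)c3c2)CC1` gives 215 nM, the highest of the two numbers at hand, while compound 1 `CC1CCN(c2nc(C(F)(F)F)ccc2CNC(=O)Nc2ccc3[nH]c(=O)ccc3c2)CC1` gives 39.9 nM. Among the measured compounds shown here, the one measured step, a 5.4-fold higher number from compound 1 to compound 2 (0.73 log units; beyond the scatter), shows that joining the same atoms of this group differently can shift the number by a modest amount. Compound 3 `CC1CCN(c2nc(C(F)(F)F)ccc2CNC(=O)Nc2ccc3ccc(=O)[nH]c3c2)CC1` differs from compound 2 by a group of 11 heavy atoms (9 carbon, 1 nitrogen, 1 oxygen; one six-membered aromatic ring of carbon only, one six-membered aromatic ring with 1 hetero atom) in place of a group of 11 heavy atoms (9 carbon, 1 nitrogen, 1 oxygen; one six-membered aromatic ring of carbon only, one six-membered aromatic ring with 1 hetero atom), on an amide-type nitrogen. For the measured compounds named here, that earlier step is the only one bearing on this change, and it gives no direction for it. Compound 3 is therefore expected to fall between the two measured numbers, the estimated step of a 2.2-fold lower number from compound 2 to compound 3 (0.33 log units; beyond the scatter) giving 100 nM in this assay, with a range of 25 nM to 400 nM.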

Compound 3, inhibition constant: 2.95 nM
Compound 3: middle estimate off by 34-fold (1.53 log units), on the high side; the measured number lies below the stated range.
By their numbers in this assay, from the lowest: compound 3; then compound 1; then compound 2.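

In this assay, rearranging the same atoms in the group on the amide-type nitrogen moves the number much further than the earlier pair showed, with a 73-fold lower number from compound 2 to compound 3 (1.86 log units; beyond the scatter) and a 14-fold lower number from compound 1 to compound 3 (1.13 log units; beyond the scatter). Among the three arrangements shown, the one in compound 3 gives the lowest number, and both of its steps lie beyond the scatter. No evidence is available that bears on this result. As far as these compounds go, whether a methyl group on the ring nitrogen of the entering group would preserve this number remains open. So does the effect of a chlorine on its carbon-only ring.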